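Swapping a Bicyclic Amide for Diisobutylamide in Chk2 Binding

This account rests on a few compounds, and the source may have more. Where it says the series, first, only, none or still open, it means among the compounds named here.

Compound 1 `COC(=O)C(CO)NC(=O)[C@@H]1CCCN1c1nccc(Oc2cccc(C)c2)n1`: 3%
Compound 2 `Cc1cccc(N(C)c2cc(Nc3cccc(C(=O)N4CCCC5CCCCC54)c3)ncn2)c1`: 2%

Among the compounds with values here, both compounds have been measured in an assay on isolated protein for inhibition of serine/threonine-protein kinase Chk2 (Homo sapiens), read by HTRF, tested at 10 uM (on this read-out lower numbers stand for less inhibition and higher numbers for more inhibition at the one concentration tested (going by the name of the read-out)), and both sit close to no inhibition at all. Compound 2 holds the lower of the two numbers, but compound 1 lies only a little higher, a gap within the usual scatter, so the two cannot be told apart.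

Compound 3 `Cc1cccc(N(C)c2cc(Nc3cccc(C(=O)N(CC(C)C)CC(C)C)c3)ncn2)c1` differs from compound 2 in one place: a group of 9 heavy atoms (8 carbon, 1 nitrogen; no ring) in place of a group of 10 heavy atoms (9 carbon, 1 nitrogen; one six-membered non-aromatic ring of carbon only, one six-membered non-aromatic ring with 1 hetero atom), on a carbonyl carbon. The two six-membered non-aromatic rings on the carbonyl carbon give way to diisobutylamino, while the rest of the molecule is unchanged.

Within the data shown here, no step between measured compounds is available to guide the size of this change. Because compound 2 gives 2% and compound 1 gives 3%, both low numbers in this assay, the expected step is a number 1 percentage points higher from compound 2 to compound 3 (within the scatter), no shift beyond the scatter. Compound 3 is therefore expected to give 3%, with a range from -6% to 12%.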

Compound 3, a percentage reported as inhibition, at one concentration (the size of the read-out at that concentration, not a potency): 0%
Compound 3: the middle estimate sits 3 percentage points above what was measured; measured number inside the range.
By their numbers in this assay, from the lowest: compounds 3, 2 and 1 (each within the scatter of the next).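

In this assay, within the data shown here, exchanging the two six-membered non-aromatic rings for diisobutylamino on the carbonyl carbon gives a number 2 percentage points lower from compound 2 to compound 3 (within the scatter) and is the first readable step at this position. The ring-bearing group and the open-chain diisobutylamino group therefore cannot be told apart here, and both compounds remain close to no inhibition, so this step says little about how the group would matter in a compound with clear inhibition. Nothing measured here offers an explanation for this result.

On these data alone, it remains open whether a much smaller group on the carbonyl carbon, such as dimethylamino, would give a different number. The same question applies to a chain ending in a carboxylic acid or a primary amine.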